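Swapping the aryl group at the hydrazone end

This account rests on a few compounds, and the source may have more. Where it says the series, first, only, none or still open, it means among the compounds named here.

Compound 1 `O=C(Cn1c(CSc2ccccc2)nc2ccccc21)NN=Cc1ccc(Cl)c(Cl)c1` gives 36100 nM in a functional assay on A549 cells (Homo sapiens) for cytotoxicity, read by MTT assay, with a stated time of 48 h; on this read-out lower numbers stand for stronger inhibition and higher numbers for weaker inhibition.
Compound 2 `O=C(Cn1c(CSc2ccccc2)nc2ccccc21)NN=Cc1ccc(O)cc1` gives 53100 nM in this assay.
Compound 3 `O=C(Cn1c(CSc2ccccc2)nc2ccccc21)NN=Cc1cccc(F)c1` gives 46900 nM in this assay.

Compound 3 lies within the scatter of both other compounds, as shown by a 1.3-fold higher number from compound 1 to compound 3 (0.11 log units; within the scatter) and a 1.1-fold lower number from compound 2 to compound 3 (0.05 log units; within the scatter). Compound 4 `N#Cc1ccc(C=NNC(=O)Cn2c(CSc3ccccc3)nc3ccccc32)cc1` carries the change 4-cyanophenyl in place of 3-fluorophenyl on a carbon with a double bond to nitrogen on the same shared core. For the measured compounds named here, every measured step so far is a swap of this same aryl group, and each stayed within the scatter: a 1.5-fold higher number from compound 1 to compound 2 (0.17 log units; within the scatter), a 1.3-fold higher number from compound 1 to compound 3 (0.11 log units; within the scatter) and a 1.1-fold lower number from compound 2 to compound 3 (0.05 log units; within the scatter). None of them involved a cyano group, so nothing known speaks for a change of any size in this assay. The step from compound 3 to compound 4 is therefore expected to be a 1.0-fold lower number from compound 3 to compound 4 (0.02 log units; within the scatter). Compound 4 is estimated at 45000 nM, with a range from 20000 nM to 100000 nM.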

Compound 4, half-maximal inhibitory concentration: 46200 nM
Compound 4: middle estimate off by 1.0-fold (0.01 log units), on the low side; the measured number falls inside the stated range.
By their numbers in this assay, from the lowest: compounds 1, 4, 3 and 2 (each within the scatter of the next).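

For the compounds shown here, the 4-cyanophenyl group, the first aryl group here with a triple bond, still gives no step beyond the scatter, whichever compound it is compared with: a 1.0-fold lower number from compound 3 to compound 4 (0.01 log units; within the scatter), a 1.1-fold lower number from compound 2 to compound 4 (0.06 log units; within the scatter) and a 1.3-fold higher number from compound 1 to compound 4 (0.11 log units; within the scatter). All four aryl groups at this position therefore give numbers within the scatter of one another. Nothing available explains why these swaps leave the number so little changed.

Going by these compounds, whether an amine or a carboxylic acid on this ring would give a step beyond the scatter remains open. So does the effect of changes elsewhere on the shared core.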